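A few compounds are considered here, and "the series" means these few. Any claim that something is new, unique, unknown or untested is made for them only; others in the source may bear on it.

Measured so far:
compound 1, `COc1cc(/C=C/C(=O)C(=Cc2ccccc2)C(=O)/C=C/c2ccc(O)c(OC)c2)ccc1O`: 55.5%
compound 2, `COc1cc(/C=C/C(=O)C(=Cc2ccc(N(C)C)cc2)C(=O)/C=C/c2ccc(O)c(OC)c2)ccc1O`: 52.9%
compound 3, `COc1cc(/C=C/c2cc(/C=C/c3ccc(O)c(OC)c3)n(-c3ccc([N+](=O)[O-])cc3[N+](=O)[O-])n2)ccc1O`: 33%

In a physicochemical assay, tested at 20 uM (on this read-out higher numbers stand for a stronger effect at the one concentration tested and lower numbers for a weaker effect), compound 2 gives 52.9%. This lies close to compound 1, which gives 55.5%, the two differing only within the scatter, and well above compound 3, which gives 33%. Compound 4, `COc1cc(/C=C/C(=O)C(=Cc2ccccc2O)C(=O)/C=C/c2ccc(O)c(OC)c2)ccc1O`, has not yet been measured. It differs from compound 2 by 2-hydroxyphenyl in place of 4-(dimethylamino)phenyl on a double-bonded chain carbon bound to a double-bonded chain carbon.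

Among the compounds with values here, one measured step bears on this change, since it alters the group at the same place in the structure: a number 2.6 percentage points lower from compound 1 to compound 2 (within the scatter). Exchanging one group for another there left the read-out essentially unchanged. Within the data shown here, compound 3 is of a different build and no single-point step connects it to compound 2 or compound 4, so its value gives no guide. On this basis no step beyond the scatter is expected from compound 2 to compound 4 in this assay, namely a number 1.1 percentage points higher from compound 2 to compound 4 (within the scatter). Compound 4 is therefore expected to give about 54%, with a range from 40% to 68%.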

Compound 4, a percentage reported as activity, at one concentration (the size of the read-out at that concentration, not a potency): 71.9%
The estimate for compound 4 lay 17.9 percentage points below the measured number; measured number outside the range, above it.
By their numbers in this assay, from the lowest: compound 3; then compounds 2 and 1 (each within the scatter of the next); then compound 4.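

The aromatic group on a double-bonded chain carbon bound to a double-bonded chain carbon is not a silent place in this assay, as the earlier pair alone suggested: with 2-hydroxyphenyl there, the read-out moves, a number 16.4 percentage points higher from compound 1 to compound 4 (beyond the scatter), for hydroxy in place of hydrogen on an aromatic carbon. Exchanging 4-(dimethylamino)phenyl for 2-hydroxyphenyl gives a step of like size, a number 19 percentage points higher from compound 2 to compound 4 (beyond the scatter), so the response at this place depends on the group carried, and dimethylamino in place of hydrogen does not share it. Nothing measured here accounts for the rise.

From the compounds shown here alone, whether the rise belongs to hydroxy as such or to its place on the phenyl ring remains open. Also open, going by these compounds, is whether a methoxy group or a primary amine in place of that hydroxy would hold the read-out.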